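This account rests on a few compounds, and the source may have more. Where it says the series, first, only, none or still open, it means among the compounds named here.

Compound 1, `COc1ccccc1-c1cc(C2CCNC2)ccc1Cl`: 970 nM
Compound 2, `COc1ccccc1-c1cc(C2CCN(C)C2)ccc1Cl`: 1000 nM
Compound 3, `CCNCc1ccc(Cl)c(-c2ccccc2OC)c1`: 1800 nM

These three compounds share one core and differ only in the group that carries the amine nitrogen. In an assay on isolated protein for binding affinity to 5-hydroxytryptamine receptor 5A (Homo sapiens) (on this read-out higher numbers stand for weaker inhibition and lower numbers for stronger inhibition), compound 3 gives 1800 nM, the highest of the three numbers shown. This does not make it the weakest binder: the step of a 1.9-fold higher number from compound 1 to compound 3 (0.27 log units; within the scatter) and the step of a 1.8-fold higher number from compound 2 to compound 3 (0.26 log units; within the scatter) both lie within the usual scatter, as does the step of a 1.0-fold higher number from compound 1 to compound 2 (0.01 log units; within the scatter), so the three numbers cannot be ranked.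

Compound 4, `CCCCNCc1ccc(Cl)c(-c2ccccc2OC)c1`, has not yet been measured in this assay. It differs from compound 3 by ethyl in place of hydrogen on a saturated chain carbon, two bonds along the chain from an amine nitrogen. Among the measured compounds shown here, none of the measured steps touches this chain; the two that replaced the whole amine-bearing group and the one that put a methyl on the nitrogen all stayed within the scatter. Because the steps of a 1.9-fold higher number from compound 1 to compound 3 (0.27 log units; within the scatter) and a 1.8-fold higher number from compound 2 to compound 3 (0.26 log units; within the scatter) changed little, no step beyond the scatter is expected here either, in neither direction. Compound 4 is therefore expected to give about 1800 nM in this assay, with a likely range from 600 nM to 5500 nM. As a step, this estimate means no change at the digits printed from compound 3 to compound 4 (within the scatter), expected to stay within the scatter.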

Compound 4, inhibition constant: 360 nM
Estimate against measurement, compound 4: 5.0-fold (0.70 log units) above; the whole stated range lies above it.
By their numbers in this assay, from the lowest: compound 4; then compounds 1, 2 and 3 (each within the scatter of the next).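

In this assay, among the compounds shown here, the change from ethylamino to butylamino gives a 5.0-fold lower number from compound 3 to compound 4 (0.70 log units; beyond the scatter) and is the first step in this set to pass beyond the scatter, so the length of the chain on this amine does register on this read-out. The butylamino group also separates compound 4 from the two compounds that carry the amine in a ring, with a 2.8-fold lower number from compound 2 to compound 4 (0.44 log units; beyond the scatter) and a 2.7-fold lower number from compound 1 to compound 4 (0.43 log units; beyond the scatter), whereas the ethylamino group of compound 3 could not be told apart from either of them, and this makes compound 4 the strongest binder of the four. The data shown offer no explanation for this gain.

With only ethyl and butyl shown on this amine, it remains open whether the number changes steadily with chain length, which a propyl group between them or a longer chain such as hexyl could test. As far as these compounds go, it is also open whether a butyl group placed on the ring nitrogen of compound 1 would give a similar step, or whether the step belongs to the open-chain amine alone.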